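The source may report more compounds than this note shows. Statements on the series, on what has been measured and on what is new or still open speak of the compounds shown alone.

Three compounds share one core and differ only in the group attached to an aromatic carbon of it. Compound 1 `Brc1cn2ccnc2c(-c2ccc3ncn(C4CCCCC4)c3c2)n1` carries a bromo there, compound 2 `c1ccc(-c2cn3ccnc3c(-c3ccc4ncn(C5CCCCC5)c4c3)n2)cc1` a phenyl, and compound 3 `Fc1ccc(-c2cn3ccnc3c(-c3ccc4ncn(C5CCCCC5)c4c3)n2)cc1` a 4-fluorophenyl. In a functional assay on U-251 cells (Homo sapiens) for inhibition, read by sulforhodamine B assay, with a stated time of 48 h, tested at 10 uM (on this read-out lower numbers stand for less inhibition and higher numbers for more inhibition at the one concentration tested (going by the name of the read-out)), compound 1 gives 1.5%, compound 2 gives 37.3%, and compound 3 gives 7.94%. Among these three numbers compound 3 stands second highest: against compound 1 the step is a number 6.4 percentage points higher from compound 1 to compound 3 (within the scatter), and against compound 2 it is a number 29.4 percentage points lower from compound 2 to compound 3 (beyond the scatter). Going by the values given here, the one step that clearly moved this assay is a number 35.8 percentage points higher from compound 1 to compound 2 (beyond the scatter).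

Compound 4 `c1cn2cc(-c3ccsc3)nc(-c3ccc4ncn(C5CCCCC5)c4c3)c2n1` is the next variation: thiophen-3-yl in place of 4-fluorophenyl on an aromatic carbon. Thiophen-3-yl is a five-membered aromatic ring with one sulfur, so it is neither the unsubstituted phenyl of compound 2 nor the fluorine-bearing ring of compound 3. The steps from compound 1 show that an aromatic ring in this place can lift inhibition strongly, as in a number 35.8 percentage points higher from compound 1 to compound 2 (beyond the scatter), or hardly at all, as in a number 6.4 percentage points higher from compound 1 to compound 3 (within the scatter). A thiophene ring is therefore expected to land somewhere between those two outcomes, with the step estimated as a number 12.1 percentage points higher from compound 3 to compound 4 (beyond the scatter), upward but uncertain. Compound 4 is accordingly estimated at 20%, within a range from 3% to 45%.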

Compound 4, a percentage reported as inhibition, at one concentration (the size of the read-out at that concentration, not a potency): 6.09%
Estimate against measurement, compound 4: 13.9 percentage points above; measured number inside the range.
By their numbers in this assay, from the lowest: compounds 1, 4 and 3 (each within the scatter of the next); then compound 2.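

In this assay, replacing the 4-fluorophenyl with thiophen-3-yl changes nothing that can be read (a number 1.9 percentage points lower from compound 3 to compound 4 (within the scatter)), and the result also stays within the scatter of the bromo compound (a number 4.6 percentage points higher from compound 1 to compound 4 (within the scatter)), whereas the same ring sits far below the plain phenyl (a number 31.2 percentage points lower from compound 2 to compound 4 (beyond the scatter)). Going by these compounds alone, this shows that having an aromatic ring at this position is not enough in itself: of the four groups, only the phenyl of compound 2 stands clearly apart, while the bromo of compound 1, the 4-fluorophenyl of compound 3 and the thiophen-3-yl of compound 4 cannot be told apart here, so the earlier loss on adding fluoro is no longer the only ring change that gives up the gain seen with phenyl. Nothing in the available information explains why phenyl stands apart from the other two rings.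

From the compounds shown here alone, it remains open whether any other ring, such as a pyridine or a phenyl carrying a methoxy group, can match or exceed the phenyl, and how a non-aromatic group such as an amine or a carboxylic acid would behave at this position. Going by these compounds, with a reading at a single concentration in one cell line, the potency of compound 2 also remains unknown.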